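Moving the methyl around a tetrazole on a saturated chain

A few compounds are considered here, and "the series" means these few. Any claim that something is new, unique, unknown or untested is made for them only; others in the source may bear on it.

Among the compounds with values here, compound 2 `CCc1cc(C(C)=O)c(O)cc1OCCCCCC(C)(C)c1nnnn1C` is one of two compounds measured in an assay on isolated protein for inhibition of leukotriene B4 receptor 1 (Homo sapiens), tested at 10 uM; a higher number here means more inhibition at the concentration tested (going by the name of the read-out), a lower number less inhibition. Compound 2 gives 99%, the lower of the two numbers, while compound 1 `CCc1cc(C(C)=O)c(O)cc1OCCCCCCC#N` gives 103%, a difference that lies within the scatter: the step of a number 4 percentage points lower from compound 1 to compound 2 (within the scatter) shows that swapping the end of the chain from cyanomethyl to 1-methyl-1-(1-methyl-1H-tetrazol-5-yl)ethyl left the read-out essentially unchanged. Compound 3 `CCc1cc(C(C)=O)c(O)cc1OCCCCCC(C)(C)c1nnn(C)n1` is not yet measured. It differs from compound 2 only in 2-methyl-2H-tetrazol-5-yl in place of 1-methyl-1H-tetrazol-5-yl on a saturated chain carbon bound to three saturated chain carbons. Within the data shown here, no measured step concerns this particular change, so the only guide is the step from compound 1 to compound 2, which was within the scatter. Compound 3 is therefore expected to give 97%, in the range 85% to 105%; the expected step of a number 2 percentage points lower from compound 2 to compound 3 (within the scatter) amounts to no change beyond the scatter.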

Compound 3, a percentage reported as inhibition, at one concentration (the size of the read-out at that concentration, not a potency): 95%
Beside the measured number, compound 3's estimate is 2 percentage points above it; low and high end bracket the measured number.
By their numbers in this assay, from the lowest: compounds 3, 2 and 1 (each within the scatter of the next).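

Moving the methyl from 1-methyl-1H-tetrazol-5-yl to 2-methyl-2H-tetrazol-5-yl, on a saturated chain carbon bound to three saturated chain carbons, gives a step in this assay of a number 4 percentage points lower from compound 2 to compound 3 (within the scatter), so this read-out does not separate the two tetrazole forms. The nitrile chain end and the 2-methyl-2H-tetrazol-5-yl chain end are not separated either, with a number 8 percentage points lower from compound 1 to compound 3 (within the scatter). No measurement at hand offers an explanation for how alike these chain ends read.

Going by these compounds, all three numbers come from a single concentration, so whether the two tetrazole forms differ in potency remains open. Also open, on these data alone, is whether a carboxylic acid or an amine at the end of the chain, or a longer chain, would read the same way.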